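The source may hold more compounds than are shown below. What is called first, only, known or untested is meant among the compounds shown, and "the series" means these compounds.

Compound 1 (`COc1cc(NC(C)CCCNC(=O)NNC(=O)Nc2ccc(F)cc2)c2ncccc2c1`) gives >= 250000 nM in a functional assay on HeLa cells (Homo sapiens) for inhibition, read by MTT assay, with a stated time of 72 h (on this read-out higher numbers stand for weaker inhibition and lower numbers for stronger inhibition), and this is a limit of the assay, not a number. Compound 2 (`COc1cc(NC(C)CCCNC(=O)NNC(=O)Nc2ccc(Cl)cc2)c2ncccc2c1`) gives 120000 nM, and compound 3 (`COc1cc(NC(C)CCCNC(=O)NNC(=O)Nc2ccc(C(F)(F)F)cc2)c2ncccc2c1`) gives 15000 nM. The measured steps are swaps on an aromatic carbon: an at least 2.0-fold lower number from compound 1 to compound 2 (0.31 log units; beyond the scatter), an at least 16-fold lower number from compound 1 to compound 3 (1.22 log units; beyond the scatter) and an 8.0-fold lower number from compound 2 to compound 3 (0.90 log units; beyond the scatter). Compound 4 (`COc1cc(NC(C)CCCNC(=O)Nc2cccc(O)c2)c2ncccc2c1`) differs from compound 1 elsewhere: 3-hydroxyphenyl in place of ((4-fluorophenyl)carbamoyl)amino on an amide-type nitrogen. Going by the values given here, no measured step touches that place, so they offer only a rough guide to size. Both steps away from compound 1 reach lower numbers, so a lower number of similar size is expected in this assay, as the estimated at least 6.2-fold lower number from compound 1 to compound 4 (0.79 log units; beyond the scatter). Compound 4 is estimated at 40000 nM, with an expected range from 10000 nM to 150000 nM.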

Compound 4, half-maximal inhibitory concentration: 48000 nM
Compound 4: middle estimate off by 1.2-fold (0.08 log units), on the low side, within the range that was stated.
By their numbers in this assay, from the lowest: compound 3; then compound 4; then compound 2. At a limit, above all of these: compound 1.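

Earlier steps changed only one substituent on an aromatic carbon, whereas this change replaces a larger group on the amide-type nitrogen. Putting 3-hydroxyphenyl in place of ((4-fluorophenyl)carbamoyl)amino gives an at least 5.2-fold lower number from compound 1 to compound 4 (0.71 log units; beyond the scatter), and the matching replacement of ((4-chlorophenyl)carbamoyl)amino gives a 2.5-fold lower number from compound 2 to compound 4 (0.40 log units; beyond the scatter), so both replacements lower the number. The first step gives only a minimum size because compound 1 stands at a limit: the limit of >= 250000 nM in this assay, at which 1 of the 4 values shown sits.

From the compounds shown here alone, whether the hydroxy group itself matters remains open. A plain phenyl or 3-methoxyphenyl group on this nitrogen would address that question.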